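Hydroxypyrrolidine amide in place of the carboxy group

This account rests on a few compounds, and the source may have more. Where it says the series, first, only, none or still open, it means among the compounds named here.

Compound 2 `Nc1ncc(-c2ccc(C(=O)O)cc2)nc1-c1ccc(C(F)(F)F)cc1` gives > 90% in an ADME assay on microsomes from liver (Mus musculus) for metabolic stability, read by LC-MS, using NADPH, with a stated time of 30 min, tested at 0.1 uM, in the presence of a further agent that is not named here; on this read-out higher numbers stand for a more stable compound and lower numbers for a less stable compound; this is a limit of the assay, not a number. Compound 1 `CS(=O)(=O)c1ccc(-c2cnc(N)c(-c3ccc(N)nc3)n2)cc1` gives > 90% in this assay, again a limit. Compound 3 `NC(=O)c1ccc(-c2cnc(N)c(-c3ccc(C(F)(F)F)cc3)n2)cc1` gives > 90% in this assay, also a limit. Among the compounds with values here, the one step that alters the carbonyl carbon, a step that the two limits leave unreadable from compound 2 to compound 3, is therefore of unreadable size, because the limit of > 90% in this assay, at which 3 of the 3 values shown sit: every value of the three compounds sits at that limit, and no step of readable size exists.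

Compound 4 `Nc1ncc(-c2ccc(C(=O)N3CC[C@@H](O)C3)cc2)nc1-c1ccc(C(F)(F)F)cc1` is formed from compound 2 by 3-hydroxypyrrolidin-1-yl in place of hydroxy on a carbonyl carbon. The only step that bears on this carbonyl carbon, from compound 2 to compound 3, was unreadable, so no direction can be drawn from the numbers shown. The step from compound 2 to compound 4 is expected to be a number at least 2 percentage points lower from compound 2 to compound 4 (that floor lies within the scatter), within the scatter. Compound 4 is estimated to give about 88% in this assay, in the range 70% to 98%, with a fair chance that the assay again reports only the limit.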

Compound 4, percent of the compound remaining: > 90%
Compound 4: a limit, no number; the forecaster's own chance of this, stated with the estimate: 55%; middle value at least 2 percentage points away from the limit.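

In this assay compound 4 gives > 90%, a limit of the assay and not a number. The steps to compound 4 from compound 2 and compound 3 cannot be read, because all the values stop at one ceiling: the limit of > 90% in this assay, at which 4 of the 4 values shown sit.

The compounds shown leave open whether any replacement on the carbonyl carbon shifts the read-out of this assay at all.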